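Swapping Methyl for Bromo on an Aromatic Carbon

The source may report more compounds than this note shows. Statements on the series, on what has been measured and on what is new or still open speak of the compounds shown alone.

Compound 1 `COC(=O)[C@@]1(C)CCC=C2[C@@H]1CC[C@@H](C)[C@]2(C)Cc1c[nH]c2ccc(F)cc12` gives 4800 nM in a functional assay on HBL-100 cells (Homo sapiens) for inhibition, read by sulforhodamine B assay, with a stated time of 48 h; a higher number here means a weaker inhibitor of growth, a lower number a stronger inhibitor of growth.
Compound 2 `COC(=O)[C@@]1(C)CC[C@@H]2C3=C1CC[C@@H](C)[C@]3(C)Cc1c2[nH]c2ccccc12` gives 3500 nM.
Compound 3 `COC(=O)[C@@]1(C)CC[C@@H]2C3=C1CC[C@@H](C)[C@]3(C)Cc1c2[nH]c2ccc(C)cc12` gives 11000 nM.

In this assay compound 3 has the highest of the three numbers, with compound 1 below it and compound 2 lower still. Among the measured compounds shown here, the one measured single change, a 3.1-fold higher number from compound 2 to compound 3 (0.50 log units; beyond the scatter), raised the number when methyl replaced hydrogen. Compound 4 `COC(=O)[C@@]1(C)CC[C@@H]2C3=C1CC[C@@H](C)[C@]3(C)Cc1c2[nH]c2ccc(Br)cc12` differs from compound 3 by bromo in place of methyl on an aromatic carbon. For the measured compounds named here, no measured pair swaps methyl for bromo, so that step is only an indirect guide: it shows how adding a group at this carbon moved the number, not how bromo compares with methyl. Compound 1, carrying fluoro on a different core, gives a lower number than compound 3. The expected change is therefore small, a 1.4-fold lower number from compound 3 to compound 4 (0.14 log units; within the scatter), with compound 4 estimated at 8000 nM within a range from 3000 nM to 25000 nM.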

Compound 4, concentration for 50% growth inhibition: 16000 nM
Compound 4: middle estimate off by 2.0-fold (0.30 log units), on the low side; measured number inside the range.
By their numbers in this assay, from the lowest: compounds 2 and 1 (each within the scatter of the next); then compounds 3 and 4 (each within the scatter of the next).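

In this assay the swap gives a 1.5-fold higher number from compound 3 to compound 4 (0.16 log units; within the scatter) and so does not separate bromo from methyl at this aromatic carbon. Against hydrogen, bromo gives a 4.6-fold higher number from compound 2 to compound 4 (0.66 log units; beyond the scatter) and so, like methyl, goes with a higher number than compound 2 shows. No available evidence gives a reason for this result. Still open, going by these compounds, is whether any group at this carbon would give a lower number than hydrogen, for instance an amine or a carboxylic acid. On these data alone, how fluoro behaves on this shared core also remains unknown.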